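A few compounds are considered here, and "the series" means these few. Any claim that something is new, unique, unknown or untested is made for them only; others in the source may bear on it.

Measured so far:
Compound 1 `CCCCCOC(=O)N1CCN(C(=O)[C@H](CCC(=O)O)NC(=O)c2cc(N3CCC(COC)CC3)nc(-c3ccccc3)n2)CC1` — > 80%
Compound 2 `CCCCCOC(=O)N1CCN(C(=O)[C@H](CCC(=O)O)NC(=O)c2cc(N3CCC(C(=O)N(CC)CC)CC3)nc(-c3ccccc3)n2)CC1` — > 80%
Compound 3 `CCCCCOC(=O)N1CCN(C(=O)[C@H](CCC(=O)O)NC(=O)c2nc(-c3ccccc3)cc(N3CCC(CN)CC3)n2)CC1` — > 80%

Each of these three readings is a limit of the assay and not a number.

In an ADME assay on microsomes from liver (Rattus norvegicus) for metabolic stability (a higher number here means that more of the compound is left, a lower number that less of the compound is left), compound 1 stands at > 80%. This is a limit of the assay, so the standing of compound 1 is known only as that limit, and the same holds for the other two members of the set, as the limit of > 80% in this assay, at which 3 of the 3 values shown sit, records. Among the measured compounds shown here, the one measured change in a single place is a step that the two limits leave unreadable from compound 1 to compound 2; its size is not readable, as both of its ends are limits. For the measured compounds named here, no other pair among the measured compounds differs in just one place.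

Compound 4 `CCCCCOC(=O)N1CCN(C(=O)[C@H](CCC(=O)O)NC(=O)c2cc(N3CCC(C(N)=O)CC3)nc(-c3ccccc3)n2)CC1` is the next member and differs from compound 1 by carbamoyl in place of methoxymethyl on a saturated ring carbon. Going by the values given here, the step bearing on it is the one from compound 1 to compound 2, which also swaps the group on that saturated ring carbon and left the reading at the limit. Among the compounds with values here, nothing among the measured steps points to a shift out of the limit region. For compound 4 a value of 85% in this assay is therefore expected, between 70% and 95%. The step that the limit leaves unreadable from compound 1 to compound 4 is expected to stay within the scatter, most likely returning a limit again.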

Compound 4, percent of the compound remaining: > 80%
Compound 4: a limit, no number; the forecaster's own chance of this, stated with the estimate: 70%; the middle value lies beyond the limit too.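

In this assay compound 4 gives > 80%, a limit of the assay and not a number. The steps to compound 4 from compound 1 and from compound 2 therefore cannot be read: the limit of > 80% in this assay, at which 4 of the 4 values shown sit. The compounds shown leave open how far these four differ in remaining compound, and which group on the saturated ring carbon would bring a reading off the limit.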